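The source may hold more compounds than are shown below. What is called first, only, known or untested is meant among the compounds shown, and "the series" means these compounds.

Measured so far in a functional assay on WI-38 VA13 cells (Homo sapiens) for cytotoxicity; a higher number here means that more compound is needed for the effect, a lower number that less compound is needed:
Compound 1 `Cc1ccccc1C(=O)Nc1ccc2nc(NC(=O)C3CCCCC3)sc2c1` gives 0.085 ug/mL.
Compound 2 `CCCC(C)C(=O)Nc1ccc2nc(NC(=O)C3CCCCC3)sc2c1` gives 0.14 ug/mL.
Compound 3 `O=C(Nc1ccc2nc(NC(=O)C3CC3)sc2c1)c1c(Cl)cccc1Cl` gives 0.013 ug/mL.

Compound 3 stands lowest of the three, and its distance to compound 1 and to compound 2 lies beyond the scatter. Compound 4 `COCCOC(=O)Nc1nc2ccc(NC(=O)c3c(Cl)cccc3Cl)cc2s1` differs from compound 3 by 2-methoxyethoxy in place of cyclopropyl on a carbonyl carbon. For the measured compounds named here, the only measured step, a 1.6-fold higher number from compound 1 to compound 2 (0.22 log units; within the scatter), also exchanges a group on a carbonyl carbon, but at a different place of the shared core, and it stayed within the scatter. Going by the values given here, no measured pair shows the exchange of a carbonyl group for a carbamate group of this kind. On that basis a modest step upward is expected, a 2.3-fold higher number from compound 3 to compound 4 (0.36 log units; beyond the scatter), with the range kept wide. Compound 4 is estimated at 0.03 ug/mL, between 0.008 ug/mL and 0.12 ug/mL.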

Compound 4, half-maximal effective concentration: 0.011 ug/mL
Compound 4: the middle estimate sits 2.7-fold (0.44 log units) above what was measured; the measured number falls inside the stated range.
By their numbers in this assay, from the lowest: compounds 4 and 3 (each within the scatter of the next); then compounds 1 and 2 (each within the scatter of the next).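

For the compounds shown here, the step of a 1.2-fold lower number from compound 3 to compound 4 (0.07 log units; within the scatter), read in this assay, is the first measured change at this carbonyl carbon. It shows that the small carbon ring of cyclopropyl can give way to 2-methoxyethoxy, an open chain holding oxygen, without the number leaving the scatter, even though the group next to the amide-type nitrogen now joins through oxygen. Nothing measured here explains this result.

On these data alone, whether an amine or a carboxylic acid at the end of this chain would also leave the number in place remains open. So does whether a longer chain would.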